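Ring substituent swap in a hydrazone series

This account rests on a few compounds, and the source may have more. Where it says the series, first, only, none or still open, it means among the compounds named here.

Compound 3 `Cn1nnnc1SCC(=O)N/N=C/c1cccc(O)c1` gives 4500000 nM in a functional assay on A549 cells (Homo sapiens) for cytotoxicity, read by XTT assay, with a stated time of 24 h (on this read-out higher numbers stand for weaker inhibition and lower numbers for stronger inhibition), the second highest of the three numbers seen so far. The parent compound 1 `Cn1nnnc1SCC(=O)N/N=C/c1ccccc1` gives 3160000 nM and the chloro analogue compound 2 `Cn1nnnc1SCC(=O)N/N=C/c1cccc(Cl)c1` gives 7500000 nM. Compound 4 `Cc1cccc(/C=N/NC(=O)CSc2nnnn2C)c1` carries methyl in place of hydroxy on an aromatic carbon, sitting on an aromatic carbon of the six-membered carbon-only ring, meta to a large group. The measured steps at that position bear on it: a 2.4-fold higher number from compound 1 to compound 2 (0.38 log units; beyond the scatter), a 1.4-fold higher number from compound 1 to compound 3 (0.15 log units; within the scatter) and a 1.7-fold lower number from compound 2 to compound 3 (0.22 log units; within the scatter). Among the measured compounds shown here, these are modest at most, and no methyl analogue has been measured, so a step within the scatter is expected for a 1.1-fold higher number from compound 3 to compound 4 (0.05 log units; within the scatter). Compound 4 is therefore estimated at 5000000 nM, with a range from 2500000 nM to 10000000 nM.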

Compound 4, half-maximal inhibitory concentration: 2000000 nM
Beside the measured number, compound 4's estimate is 2.5-fold (0.40 log units) above it; the measured number lies below the stated range.
By their numbers in this assay, from the lowest: compounds 4, 1, 3 and 2 (each within the scatter of the next, the first and the last beyond it).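

In this assay, among the compounds shown here, methyl gives the first downward steps at this position that lie beyond the scatter: a 2.3-fold lower number from compound 3 to compound 4 (0.35 log units; beyond the scatter) and a 3.8-fold lower number from compound 2 to compound 4 (0.57 log units; beyond the scatter). Against the unsubstituted parent the same group is not separated, with a 1.6-fold lower number from compound 1 to compound 4 (0.20 log units; within the scatter), so the series so far separates methyl from hydroxy and chloro, but not from hydrogen. Nothing available gives a reason for these steps.

On these data alone, whether an amine, a methoxy group or a carboxylic acid at this place would move the number further stays open. So does whether methyl gives the same steps elsewhere on the ring.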